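From butoxy to cyclopropylmethoxy

A few compounds are considered here, and "the series" means these few. Any claim that something is new, unique, unknown or untested is made for them only; others in the source may bear on it.

In a functional assay on the whole organism (strain Sprague-Dawley) for inhibition, with Rattus norvegicus as the target, with a stated time of 10 min (on this read-out higher numbers stand for an effect only at larger amounts of compound and lower numbers for an effect already at smaller amounts), compound 1 `CCOC(=O)c1cnc(-c2ccccc2Cl)[nH]c1=O` gives 5 mg/kg and compound 2 `CCCCOc1ccccc1-c1ncc(C(=O)OCC)c(=O)[nH]1` gives 0.5 mg/kg as the lower of the two numbers. Butoxy in place of chloro brought a 10-fold lower number from compound 1 to compound 2 (1.00 log units; beyond the scatter) as the only measured step, but no measured step alters the chain itself. Compound 3 `CCOC(=O)c1cnc(-c2ccccc2OCC2CC2)[nH]c1=O` does alter it, with cyclopropyl in place of propyl on a saturated chain carbon bound to an oxygen on an aromatic ring as the difference: cyclopropyl in place of propyl, turning butoxy into cyclopropylmethoxy. The estimate therefore starts from compound 2 at 0.5 mg/kg and expects no step beyond the scatter in this assay for this change. An estimated 1.2-fold higher number from compound 2 to compound 3 (0.08 log units; within the scatter) is all that is expected. For compound 3 the estimated value is 0.6 mg/kg with 0.2 mg/kg to 1.8 mg/kg as the expected range.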

Compound 3, dose for 50% inhibition: 0.3 mg/kg
Compound 3: middle estimate off by 2.0-fold (0.30 log units), on the high side; the measured number falls inside the stated range.
By their numbers in this assay, from the lowest: compounds 3 and 2 (each within the scatter of the next); then compound 1.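

In this assay, closing the end of the chain into a three-membered ring, with cyclopropyl in place of propyl, gives a 1.7-fold lower number from compound 2 to compound 3 (0.22 log units; within the scatter), so this change leaves the number where it was. Cyclopropylmethoxy in place of chloro gives a 17-fold lower number from compound 1 to compound 3 (1.22 log units; beyond the scatter), so butoxy is no longer the only group at this position shown to stand clearly apart from chloro. Nothing measured here explains these numbers. From the compounds shown here alone, whether a longer chain, such as hexyloxy, or an amine at the end of the chain would hold this level remains open.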